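A few compounds are considered here, and "the series" means these few. Any claim that something is new, unique, unknown or untested is made for them only; others in the source may bear on it.

In a functional assay on MCF7 cells (Homo sapiens) for cytotoxicity, read by MTT assay, with a stated time of 72 h (a lower number here means a stronger inhibitor, a higher number a weaker inhibitor), compound 1 `O=C(CCl)Nc1ccc(C(=O)/C=C/c2ccccc2)cc1` gives 2480 nM. Compound 2 `O=C(CCl)Nc1ccc(C(=O)/C=C/c2ccccc2Cl)cc1` gives 5260 nM, and compound 3 `O=C(CCl)Nc1ccc(C(=O)/C=C/c2cccc(Cl)c2)cc1` gives 5340 nM. Compound 3 therefore stands level with compound 2, and both numbers are higher than that of compound 1.

Compound 4 `O=C(CSC(=S)N[C@H]1CCOC1=O)Nc1ccc(C(=O)/C=C/c2cccc(Cl)c2)cc1` differs from compound 3 in another part of the molecule: a group of 10 heavy atoms (5 carbon, 1 nitrogen, 2 oxygen, 2 sulfur; one five-membered non-aromatic ring with 1 hetero atom) in place of one chlorine atom, on a saturated chain carbon bound to a carbonyl carbon. The chlorine that leaves sits on a saturated chain carbon bound to a carbonyl carbon.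

The measured steps are all small. Chloro in place of hydrogen on an aromatic carbon gives a 2.1-fold higher number from compound 1 to compound 2 (0.33 log units; beyond the scatter) and a 2.2-fold higher number from compound 1 to compound 3 (0.33 log units; beyond the scatter), both modest. Moving the chlorine gives a 1.0-fold higher number from compound 2 to compound 3 (0.01 log units; within the scatter), which is within the scatter. None of these steps touches the saturated chain carbon, so the data give no direction for this much larger change. No step beyond the scatter is expected, but the range must stay wide.

The expected step is a 1.3-fold lower number from compound 3 to compound 4 (0.13 log units; within the scatter). The estimate for compound 4 is 4000 nM, with an expected range from 800 nM to 20000 nM.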

Compound 4, half-maximal inhibitory concentration: 11600 nM
For compound 4 the middle estimate is 2.9-fold (0.46 log units) below the measured one; measured number inside the range.
By their numbers in this assay, from the lowest: compound 1; then compounds 2 and 3 (each within the scatter of the next); then compound 4.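

In this assay the saturated chain carbon bound to a carbonyl carbon proves sensitive to what it carries, with a 2.2-fold higher number from compound 3 to compound 4 (0.34 log units; beyond the scatter) as a modest step beyond the scatter. This change is far larger than the chlorine changes on the aromatic ring, yet its step is of similar size, so swapping one chlorine atom for a group of 10 heavy atoms with a five-membered non-aromatic ring weakens the number without abolishing the activity. No measurement here explains this step.

With a single replacement shown at this carbon, it stays open whether a small group, such as a simple amine or a methyl group, would give a lower or a higher number than the chlorine. Going by these compounds, it also stays open whether the same large group would give a similar step on compound 1 or compound 2.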